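Fluoro in Place of Trifluoromethyl: Compound 1 to Compound 4

The source may report more compounds than this note shows. Statements on the series, on what has been measured and on what is new or still open speak of the compounds shown alone.

Measured compounds:
compound 1 `CC(C(=O)N1CCN(c2ccccc2C(F)(F)F)CC1)N1C(=O)CCC1=O` – 0%
compound 2 `COCC(C(=O)N1CCN(c2cccc(C(F)(F)F)c2)CC1)N1C(=O)CCC1=O` – 0%
compound 3 `CCC(C(=O)N1CCN(c2ccccc2)CC1)N1C(=O)CCC1=O` – 0%

In a functional assay on the whole organism (strain Swiss) with Mus musculus as the target, in the maximal electroshock model, with a stated time of 2 h, at a dose of 100 mg/kg by the intraperitoneal route (on this read-out higher numbers stand for a stronger effect at the one dose given and lower numbers for a weaker effect), compound 1 gives 0%, and compounds 2 and 3 stand level with it at the digits shown; none of the three differs from another beyond the scatter, so no order among them can be read. Compound 4 `CC(C(=O)N1CCN(c2ccccc2F)CC1)N1C(=O)CCC1=O` is not yet measured. It differs from compound 1 by fluoro in place of trifluoromethyl on an aromatic carbon. Going by the values given here, no step between measured compounds bears on this change, and all three measured values sit at the floor of this assay. The change from compound 1 to compound 4 is therefore expected to bring no step beyond the scatter, no change at the digits printed from compound 1 to compound 4 (within the scatter). Compound 4 is estimated at 0%, within a range from 0% to 15%.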

Compound 4, a percentage reported as activity, at one dose (the size of the read-out at that dose, not a potency): 0%
Compound 4: middle estimate and measured number agree at the digits printed, and the stated range covers the measured number.
By their numbers in this assay, from the lowest: compounds 1, 2, 3 and 4 (each within the scatter of the next).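

In this assay, fluoro in place of trifluoromethyl on an aromatic carbon brings no change at the digits printed from compound 1 to compound 4 (within the scatter), the first step read between two compounds that differ in one place. At this position, replacing a group of 4 heavy atoms with one of 1 heavy atom does not lift the read-out from its floor at the one dose given. Nothing measured here offers an explanation for this result.

A step at the floor cannot show whether either group matters when the core gives a measurable effect. As far as these compounds go, it also remains open whether an amine, a carboxylic acid or a longer chain at this position would give a read-out above the floor.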